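Fluoro for Ethyl on the Fused Ring of Compound 2

The compounds below may be only part of what the source reports. "The series", "measured", "known", "first", "only" and "open" are said of these compounds alone.

Compound 1 `Cc1ccc2nc(C(=O)Nc3c(F)cc(-c4cccc(F)c4)cc3F)c(C)c(C(=O)O)c2c1` and compound 2 `CCc1ccc2nc(C(=O)Nc3c(F)cc(-c4cccc(F)c4)cc3F)c(C)c(C(=O)O)c2c1` share one core and differ in a single place. In a functional assay on Hep 3B2 cells (Homo sapiens) for antiproliferative activity, read by MTT assay, with a stated time of 24 h, tested at 3.7 ug/mL (on this read-out lower numbers stand for a weaker effect and higher numbers for a stronger effect at the one concentration tested), compound 1 gives 31.3%, and compound 2 gives 15.2%. Going by the values given here, the only measured step is a number 16.1 percentage points lower from compound 1 to compound 2 (beyond the scatter). On these two numbers compound 2 stands lowest, with compound 1 as its nearest neighbour and the gap beyond the scatter. Compound 3 `Cc1c(C(=O)Nc2c(F)cc(-c3cccc(F)c3)cc2F)nc2ccc(F)cc2c1C(=O)O` has not yet been measured; it differs from compound 2 by fluoro in place of ethyl on an aromatic carbon. The measured step bears on this change because the ethyl that leaves arose in a number 16.1 percentage points lower from compound 1 to compound 2 (beyond the scatter) through methyl in place of hydrogen on a saturated chain carbon bound to an aromatic carbon, and that addition weakened the effect. Removing the ethyl for a fluoro is therefore expected to give a modest rise for compound 3, a number 14.8 percentage points higher from compound 2 to compound 3 (beyond the scatter). The estimate for compound 3 is 30%, expected between 12% and 48%.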

Compound 3, a percentage reported as inhibition, at one concentration (the size of the read-out at that concentration, not a potency): 11.2%
Estimate against measurement, compound 3: 18.8 percentage points above; the whole stated range lies above it.
By their numbers in this assay, from the lowest: compounds 3 and 2 (each within the scatter of the next); then compound 1.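

In this assay, fluoro in place of ethyl on this aromatic carbon gives a number 4 percentage points lower from compound 2 to compound 3 (within the scatter), so this read-out does not separate these two groups at this position. Fluoro in place of methyl gives a number 20.1 percentage points lower from compound 1 to compound 3 (beyond the scatter), which shows that removing the ethyl does not by itself restore the level of compound 1 and that, of the three groups shown, only the methyl stands apart. The material at hand offers nothing that accounts for this result.

The compounds shown leave open how a chloro, a methoxy or an amine at this position would compare with the methyl of compound 1. They also leave open whether the methyl keeps its margin over ethyl and fluoro at other concentrations or in other cell lines.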